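Hydroxy in place of fluoro: working notes

The source may report more compounds than this note shows. Statements on the series, on what has been measured and on what is new or still open speak of the compounds shown alone.

Measured so far in a functional assay (Homo sapiens) for inhibition (on this read-out lower numbers stand for stronger inhibition and higher numbers for weaker inhibition), for the series:
- compound 1 `COc1cc(/C=C/C(=O)c2cccc(N(C)C)c2)cc(OC)c1` gives 5000 nM
- compound 2 `COc1cc(/C=C/C(=O)c2cccc(F)c2)cc(OC)c1` gives 9200 nM

Among the measured compounds shown here, compound 2 (9200 nM) lies within the scatter of compound 1 (5000 nM), the only other measured compound, so the two read as level. Not yet measured is compound 3 `COc1cc(/C=C/C(=O)c2cccc(O)c2)cc(OC)c1`. The structural change to it is hydroxy in place of fluoro on an aromatic carbon and reads as hydroxy in place of fluoro on an aromatic carbon, meta to a large group. For the measured compounds named here, one measured step bears on this: a 1.8-fold higher number from compound 1 to compound 2 (0.26 log units; within the scatter) is a swap on an aromatic carbon, fluoro in place of dimethylamino, and it stays within the scatter. Going by the values given here, that single step is thin support, and no hydroxy compound has been measured, so the direction in this assay remains open. No change beyond the scatter is therefore expected, and the expected step is a 1.4-fold lower number from compound 2 to compound 3 (0.15 log units; within the scatter) as a rough estimate. For compound 3 the estimated value is 6500 nM with an expected range of 2200 nM to 18000 nM in this series.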

Compound 3, half-maximal inhibitory concentration: 3200 nM
Beside the measured number, compound 3's estimate is 2.0-fold (0.31 log units) above it; low and high end bracket the measured number.
By their numbers in this assay, from the lowest: compounds 3, 1 and 2 (each within the scatter of the next, the first and the last beyond it).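

In this assay, hydroxy in place of fluoro on an aromatic carbon, meta to a large group, gives a 2.9-fold lower number from compound 2 to compound 3 (0.46 log units; beyond the scatter) and is the only step among the compounds shown that lies beyond the scatter, so the read-out at this position does respond to the group placed there, if only modestly. Hydroxy in place of dimethylamino gives a 1.6-fold lower number from compound 1 to compound 3 (0.19 log units; within the scatter) and stays within the scatter, so compound 1 and compound 3 read as level, and compound 1 is also level with compound 2: dimethylamino cannot be set apart from either of the other two groups, and only 3-fluorophenyl and 3-hydroxyphenyl separate. No measurement at hand accounts for the step between these two groups.

As far as these compounds go, whether a primary amine, a carboxylic acid or a chloro group at this position would read with hydroxy, with fluoro or outside both stays open. Also open, from the compounds shown here alone, is whether hydroxy in place of fluoro gives a step of similar size on another aromatic carbon or on another core.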